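Removing a Chlorine from a Cytotoxic Purine

The source may report more compounds than this note shows. Statements on the series, on what has been measured and on what is new or still open speak of the compounds shown alone.

Three compounds that share a chlorinated purine core carrying a benzyl group with a chloromethyl substituent have been tested in a functional assay on NCI-H23 cells (Homo sapiens) for cytotoxicity, read by sulforhodamine B assay, with a stated time of 48 h; on this read-out lower numbers stand for higher toxicity in this test and higher numbers for lower toxicity in this test. Compound 1 `ClCc1ccc(Cn2cnc3nc(Cl)nc(Cl)c32)cc1` gives 8910 nM in this assay. Compound 2 `Nc1nc(Cl)c2ncn(Cc3cccc(CCl)c3)c2n1`, in which an amino group replaces one of the two chloro groups on the core and the chloromethyl group sits elsewhere on the benzyl ring, gives 26900 nM. Compound 3 `ClCc1ccccc1Cn1cnc2nc(Cl)nc(Cl)c21`, where the chloromethyl group again sits elsewhere on the benzyl ring, gives 87100 nM. On these numbers compound 1 stands as the most toxic of the three: compound 2 is beyond the scatter above it, and compound 3 lies further still.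

Compound 4 `ClCc1ccc(Cn2cnc3ncnc(Cl)c32)cc1` has not yet been measured. It differs from compound 1 by hydrogen in place of chloro on an aromatic carbon. Within the data shown here, no measured pair shows this change on its own, so the size of its effect is open. A moderate loss of toxicity is expected in this assay, with a step from compound 1 to compound 4 of about a 2.0-fold higher number from compound 1 to compound 4 (0.31 log units; beyond the scatter). Compound 4 is therefore estimated at 18000 nM, with a range from 5000 nM to 60000 nM.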

Compound 4, concentration lethal to 50% of the cells: 58900 nM
Beside the measured number, compound 4's estimate is 3.3-fold (0.51 log units) below it; the measured number falls inside the stated range.
By their numbers in this assay, from the lowest: compound 1; then compound 2; then compounds 4 and 3 (each within the scatter of the next).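

Among these compounds, this is the first reading of a single change on the shared core: in this assay, replacing the chloro group on the aromatic carbon between two ring nitrogen atoms with hydrogen gives a 6.6-fold higher number from compound 1 to compound 4 (0.82 log units; beyond the scatter). The earlier compounds shown here could not isolate this effect, as compound 2 and compound 3 each differ from compound 1 in the place of the chloromethyl group, and compound 2 also carries an amino group on the core. The result therefore shows that this chloro group matters on its own for the read-out: with the benzyl group, its chloromethyl substituent and the remaining chloro group unchanged, its loss alone leaves compound 4 clearly less toxic in this test than compound 1.

No measurement at hand explains why this step occurs. The compounds shown also leave open how a methoxy group or a bromine atom on this same carbon would compare with chloro and hydrogen, and whether the step would keep its size with the chloromethyl group elsewhere on the benzyl ring.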